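Series notes: amide variation on the shared core

The source may hold more compounds than are shown below. What is called first, only, known or untested is meant among the compounds shown, and "the series" means these compounds.

Measured so far:
- Compound 1 `CCN(CC)S(=O)(=O)c1ccc(S(=O)(=O)N2CCC[C@@H](C(=O)N3CCC(C(F)(F)F)CC3)C2)cc1`: in a functional assay on MIA PaCa-2 cells (Homo sapiens) for inhibition, read by MTT assay, with a stated time of 3 days (a higher number here means a weaker inhibitor, a lower number a stronger inhibitor), compound 1 gives > 10000 nM, which is a limit of the assay.
- Compound 2 `CCN(CC)S(=O)(=O)c1ccc(S(=O)(=O)N2CCC[C@@H](C(=O)N[C@@H]3CCOC3)C2)cc1`: in this assay compound 2 gives > 10000 nM, also a limit, not a number.

Compound 2 therefore stands only at the limit of > 10000 nM in this assay, at which 2 of the 2 values shown sit, with no number of its own. Among the measured compounds shown here, the one measured step, a step that the two limits leave unreadable from compound 1 to compound 2, is unreadable for the same reason. Compound 3 `CCN(CC)S(=O)(=O)c1ccc(S(=O)(=O)N2CCC[C@@H](C(=O)N3CC[C@@H](OC)C3)C2)cc1` differs from compound 2 by 3-methoxypyrrolidin-1-yl in place of (oxolan-3-yl)amino on a carbonyl carbon. For the measured compounds named here, no measured step bears on this change, and both neighbours sit at the limit, so no movement beyond the scatter is expected; the estimated step is a step that the limit leaves unreadable from compound 2 to compound 3. Compound 3 is expected at 15000 nM, within 5000 nM to 50000 nM, most likely reported again as a limit.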

Compound 3, half-maximal inhibitory concentration: > 10000 nM
Compound 3 was reported as a limit (the forecaster's own chance of this, stated with the estimate: 75%); the middle value does not contradict the limit.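

No step among compound 1, compound 2 and compound 3 can be read, because each result is a limit and not a number: the limit of > 10000 nM in this assay, at which 3 of the 3 values shown sit.

Going by these compounds, whether any amide on the shared core gives a number rather than a limit stays open.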